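The source may hold more compounds than are shown below. What is called first, only, known or untested is meant among the compounds shown, and "the series" means these compounds.

In a functional assay on CHO cells with adenosine receptor A1 (Homo sapiens) as the target, read by cAMP accumulation and immunoassay, with a stated time of 6 min, tested at 10 uM (on this read-out higher numbers stand for a weaker effect at the one concentration tested and lower numbers for a stronger effect), compound 1 `Nc1scc(CN2CCN(c3c(F)cccc3F)CC2)c1C(=O)c1ccc(Cl)cc1` gives -80% and compound 2 `Nc1scc(CN2CCN(c3c(F)cc(F)cc3F)CC2)c1C(=O)c1ccc(Cl)cc1` gives -78%; the two lie within the scatter of each other, with a number 2 percentage points higher from compound 1 to compound 2 (within the scatter). Compound 3 `Nc1scc(CN2CCN(c3ccccc3Cl)CC2)c1C(=O)c1ccc(Cl)cc1` is not yet measured. (2-chlorophenyl in place of 2,4,6-trifluorophenyl on an amine nitrogen in a ring). Among the measured compounds shown here, the only measured step covers fluoro in place of hydrogen on an aromatic carbon, and it stayed within the scatter; no measured step exchanges the whole aryl group, so the change is judged from that one step alone. The step of a number 2 percentage points higher from compound 2 to compound 3 (within the scatter) is therefore expected to stay within the scatter, in no clear direction. Compound 3 is estimated at -76%, between -92% and -55%.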

Compound 3, a percentage reported as activity, at one concentration (the size of the read-out at that concentration, not a potency): -18%
Beside the measured number, compound 3's estimate is 58 percentage points below it, outside the stated range (above it).
By their numbers in this assay, from the lowest: compounds 1 and 2 (each within the scatter of the next); then compound 3.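

With a number 60 percentage points higher from compound 2 to compound 3 (beyond the scatter) and a number 62 percentage points higher from compound 1 to compound 3 (beyond the scatter) in this assay, the aryl group on the amine nitrogen in a ring emerges as a sensitive point in the series. Among the compounds shown here, exchanging the whole aryl group moves the read-out far more than adding one fluoro did, where the only earlier step was a number 2 percentage points higher from compound 1 to compound 2 (within the scatter) and stayed small. Nothing available explains the shift.

Still open, going by these compounds, is whether the shift follows the chlorine itself or the absence of the fluoro groups. A plain phenyl or 2-methoxyphenyl group at this place would bear on that question.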